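Compound 3 and its 2-fluorophenyl counterpart, compound 4

This account rests on a few compounds, and the source may have more. Where it says the series, first, only, none or still open, it means among the compounds named here.

Among the compounds with values here, in a functional assay on MCF7 cells (Homo sapiens) for antiproliferative activity, read by MTT assay (on this read-out lower numbers stand for stronger inhibition and higher numbers for weaker inhibition), compound 3 (`COc1cc2c(Oc3ccc(NC(=O)Nc4ccc(C(F)(F)F)cc4Cl)cc3)ccnc2cc1OCCCCCCC(=O)NO`) gives 500 nM, the lowest of the three numbers measured so far. Compound 1 (`COc1cc2c(Oc3ccc(NC(=O)Nc4ccccc4Cl)cc3)ccnc2cc1OCCCCCCC(=O)NO`) gives 2780 nM and compound 2 (`COc1cc2c(Oc3ccc(NC(=O)Nc4ccc(OC(F)(F)F)cc4)cc3)ccnc2cc1OCCCCCCC(=O)NO`) gives 3200 nM, and these two sit within the scatter of each other, as a 1.2-fold higher number from compound 1 to compound 2 (0.06 log units; within the scatter) shows. Compound 4 (`COc1cc2c(Oc3ccc(NC(=O)Nc4ccccc4F)cc3)ccnc2cc1OCCCCCCC(=O)NO`) has 2-fluorophenyl in place of 2-chloro-4-(trifluoromethyl)phenyl on an amide-type nitrogen. The nearest measured change is a 5.6-fold lower number from compound 1 to compound 3 (0.75 log units; beyond the scatter), which adds trifluoromethyl on an aromatic carbon, and a 6.4-fold lower number from compound 2 to compound 3 (0.81 log units; beyond the scatter) is of similar size. Read in reverse, both point to a rise in this assay, and the expected change is a 5.0-fold higher number from compound 3 to compound 4 (0.70 log units; beyond the scatter). Compound 4 is estimated at 2500 nM, within a range of 1000 nM to 6000 nM.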

Compound 4, half-maximal inhibitory concentration: 660 nM
Estimate against measurement, compound 4: 3.8-fold (0.58 log units) above; the measured number lies below the stated range.
By their numbers in this assay, from the lowest: compounds 3 and 4 (each within the scatter of the next); then compounds 1 and 2 (each within the scatter of the next).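

In this assay the 2-fluorophenyl group on this amide-type nitrogen performs on a par with 2-chloro-4-(trifluoromethyl)phenyl (a 1.3-fold higher number from compound 3 to compound 4 (0.12 log units; within the scatter)), so trifluoromethyl is not needed for a low number here. Fluoro in place of chloro alone moves the number beyond the scatter (a 4.2-fold lower number from compound 1 to compound 4 (0.62 log units; beyond the scatter)), and 2-fluorophenyl also separates clearly from 4-(trifluoromethoxy)phenyl (a 4.8-fold lower number from compound 2 to compound 4 (0.69 log units; beyond the scatter)). No measurement at hand accounts for these steps. As far as these compounds go, whether a plain phenyl, or a methoxy or nitrile on that ring, would behave like fluoro remains open.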